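Swapping Fluoro for Chloro Beside a Ring Nitrogen

A few compounds are considered here, and "the series" means these few. Any claim that something is new, unique, unknown or untested is made for them only; others in the source may bear on it.

Compound 1 `O=C(O)Cc1sc(C(c2ccccc2)c2ccc(Cl)cc2)nc1-c1ccc(Cl)cc1`: in an in vitro assay on HEK385-7 cells for displacement of a labelled ligand from prostaglandin D2 receptor 2 (Homo sapiens) (a higher number here means a weaker inhibitor, a lower number a stronger inhibitor), compound 1 gives 45 nM.
Compound 2 `O=C(O)Cc1sc(C(c2ccccc2)c2ccc(Cl)cc2)nc1-c1ccc(F)cc1`: in this assay compound 2 gives 14 nM.
Compound 3 `O=C(O)Cc1sc(C(c2ccc(F)cc2)c2ccc(F)cc2)nc1-c1ccnc(F)c1`: in this assay compound 3 gives 0.48 nM.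

Compound 4 `O=C(O)Cc1sc(C(c2ccc(F)cc2)c2ccc(F)cc2)nc1-c1ccnc(Cl)c1` has not yet been measured. The difference between the cores of compound 2 and compound 3 is not broken down here; compound 3 gives the lowest number of the three. Compound 2 and compound 1 differ by one change, (chloro in place of fluoro on an aromatic carbon), which produced a 3.2-fold higher number from compound 2 to compound 1 (0.51 log units; beyond the scatter). Compound 3 and compound 4 differ by the same kind of change, (chloro in place of fluoro on an aromatic carbon), but the place is not the same: here the ring is a six-membered aromatic ring with 1 nitrogen, next to the ring nitrogen, meta to a large group, rather than a ring of carbon only, para to a large group. Given a 3.2-fold higher number from compound 2 to compound 1 (0.51 log units; beyond the scatter), a weakening of similar size is expected, a 2.5-fold higher number from compound 3 to compound 4 (0.40 log units; beyond the scatter). Compound 4 is thus estimated at 1.2 nM, with a likely range from 0.4 nM to 4 nM.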

Compound 4, half-maximal inhibitory concentration: 3.1 nM
For compound 4 the middle estimate is 2.6-fold (0.41 log units) below the measured one; the range from low to high includes it.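

In this assay, chloro in place of fluoro next to the ring nitrogen gives a 6.5-fold higher number from compound 3 to compound 4 (0.81 log units; beyond the scatter), so the change weakens the inhibitor on both cores, and the two steps can be read as one effect of similar size: the same change on two cores in this assay, a 3.2-fold higher number (0.51 log units; beyond the scatter) from compound 2 to compound 1 and a 6.5-fold higher number (0.81 log units; beyond the scatter) from compound 3 to compound 4, 2.0-fold (0.30 log units) apart, within the scatter of two such steps

Going by these compounds alone, this rests on only two pairs, with the change at a different place in each, so it does not show that the swap will cost the same across the whole series.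

Going by these compounds, it remains open how hydrogen, methyl, methoxy or a nitrile on that same aromatic carbon would compare with fluoro in compound 3, at 0.48 nM.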